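Series notes: amine swap at the core of compound 2

This account rests on a few compounds, and the source may have more. Where it says the series, first, only, none or still open, it means among the compounds named here.

Of the compounds shown here, two have been measured in a functional assay on L02 cells (Homo sapiens) for inhibition, read by Griess assay, with stated times of 1 h and 24 h; on this read-out higher numbers stand for weaker inhibition and lower numbers for stronger inhibition. Compound 1 `CCCc1nn(C)c2c(NCc3ccc(F)cc3)nc(/C=C/c3cccnc3)nc12` gives 940000 nM. Compound 2 `COc1cc(/C=C/c2nc(N3CCN(C)CC3)c3sccc3n2)cc(OC)c1OC` yields only a limit, > 1000000 nM, so compound 2 stands at the limit of > 1000000 nM in this assay, at which 1 of the 2 values shown sits, and has no number in this assay. Compound 3 `COc1cc(/C=C/c2nc(NCc3ccc(Cl)cc3)c3sccc3n2)cc(OC)c1OC` differs from compound 2 by (4-chlorobenzyl)amino in place of 4-methylpiperazin-1-yl on an aromatic carbon. Within the data shown here, no measured pair differs in one place, so no step size is known from the data. Compound 1, which gives 940000 nM, points to weak inhibition for this kind of substituent. Compound 3 is therefore expected near 900000 nM, between 300000 nM and 3000000 nM. The expected step is an at least 1.1-fold lower number from compound 2 to compound 3 (0.04 log units; that floor lies within the scatter), not beyond the scatter.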

Compound 3, half-maximal inhibitory concentration: > 1000000 nM
Compound 3 ended at the assay's limit; the forecaster's own chance of this, stated with the estimate: 50%; middle value at least 1.1-fold (0.04 log units) from the limit.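

No step can be read between compound 2 and compound 3, since both stand at a limit and not at a number: the limit of > 1000000 nM in this assay, at which 2 of the 3 values shown sit.

The compounds shown leave open whether (4-chlorobenzyl)amino in place of 4-methylpiperazin-1-yl changes inhibition at all in this assay.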